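This account rests on a few compounds, and the source may have more. Where it says the series, first, only, none or still open, it means among the compounds named here.

Working notes on the series.

Compound 1 `CC1CCN(c2c(S(=O)(=O)c3ccccc3)cnc3cc(Cl)ccc23)CC1` is the reference point. For the measured compounds named here, in an assay on isolated protein for displacement of a labelled ligand from metabotropic glutamate receptor 5 (Homo sapiens), with a stated time of 60 min, tested at 1 uM (a lower number here means less inhibition, a higher number more inhibition at the concentration tested (going by the name of the read-out)), compound 1 gives 93%, the highest of the three numbers so far, though the other two lie within the usual scatter of it. Compound 2 `COc1ccc(S(=O)(=O)c2cnc3cc(F)ccc3c2N2CCC(C)CC2)cc1` gives 90% and compound 3 `CC1CCN(c2c(S(=O)(=O)c3ccccc3)cnc3ccccc23)CC1` gives 89.2%. Going by the values given here, the one single-point step among the measured compounds, a number 3.8 percentage points lower from compound 1 to compound 3 (within the scatter), concerns the core of compound 1 and does not cross the scatter.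

Compound 4 `CC1CCN(c2c(S(=O)(=O)c3ccc(C#N)cc3)cnc3cc(Cl)ccc23)CC1` differs from compound 1 in one place: cyano in place of hydrogen on an aromatic carbon. Among the compounds with values here, no measured step touches this ring of the sulfonyl group directly. Compound 2 carries a methoxy group on that ring together with a fluoro on the core, but as it differs from compound 1 in two places only its two values can be compared, and they sit within the scatter of each other. Within the data shown here, the single measured step, from a hydrogen in place of chloro elsewhere, was also within the scatter. With all three numbers lying close together and high, no step beyond the scatter is expected in this assay for compound 4; the expected step is a number 3 percentage points lower from compound 1 to compound 4 (within the scatter). Compound 4 is therefore estimated at 90%, with a range of 78% to 97%.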

Compound 4, a percentage reported as inhibition, at one concentration (the size of the read-out at that concentration, not a potency): 70%
Compound 4: middle estimate off by 20 percentage points, on the high side, and the stated range ends above it.
By their numbers in this assay, from the lowest: compound 4; then compounds 3, 2 and 1 (each within the scatter of the next).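

For the compounds shown here, the phenyl to 4-cyanophenyl change is the first single change to cross the scatter: in this assay it gives a number 23 percentage points lower from compound 1 to compound 4 (beyond the scatter), whereas the one earlier step, on the core, gave a number 3.8 percentage points lower from compound 1 to compound 3 (within the scatter). The ring on the sulfonyl group is therefore not a neutral place for substitution, at least for cyano on the aromatic carbon para to a large group, and this could not be read from compound 2, which differs from compound 1 in two places. Nothing at hand accounts for the lower number.

Going by these compounds alone, it remains open whether the drop belongs to cyano in particular or to any group at this place, as the series offers only this one single change on the ring, read at one concentration and not as a potency. A methyl, a carboxylic acid or a primary amine at the same carbon would separate these readings, and cyano on the ring of compound 3 would show whether the step holds without the chloro on the core.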